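Phenyl in Place of Formyl on a Ring Nitrogen

The source may hold more compounds than are shown below. What is called first, only, known or untested is meant among the compounds shown, and "the series" means these compounds.

Three compounds have been measured in a functional assay on the whole organism (strain Wistar) for inhibition, with Rattus norvegicus as the target, read by paw edema, with stated times of 30 min and 60 min, at a dose of 50 mg/kg by the oral route; on this read-out lower numbers stand for less inhibition and higher numbers for more inhibition at the one dose given (going by the name of the read-out):
compound 1, `O=CN1N=C(c2ccc(F)cc2)CC1c1cn(-c2ccccc2)nc1-c1ccc(Cl)c(Cl)c1`, gives 56.5%;
compound 2, `Fc1ccc(C2=NN(c3ccccc3)C(c3cn(-c4ccccc4)nc3-c3ccc(Cl)c(Cl)c3)C2)cc1`, gives 55.7%;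
compound 3, `Cc1ccc(C2=NN(C=O)C(c3cn(-c4ccccc4)nc3-c3ccc(Cl)c(Cl)c3)C2)cc1`, gives 53.4%.

Compound 2 differs from compound 1 by phenyl in place of formyl on an amine nitrogen in a ring, and this change gave a number 0.8 percentage points lower from compound 1 to compound 2 (within the scatter). Compound 4, `Cc1ccc(C2=NN(c3ccccc3)C(c3cn(-c4ccccc4)nc3-c3ccc(Cl)c(Cl)c3)C2)cc1`, is not yet measured; it differs from compound 3 by phenyl in place of formyl on an amine nitrogen in a ring. The two cores differ by methyl in place of fluoro on an aromatic carbon, with a number 3.1 percentage points lower from compound 1 to compound 3 (within the scatter). The surroundings of the change are not identical: in one pair the ring carries a 4-fluorophenyl group two ring bonds away, in the other a 4-methylphenyl group, so this is the same kind of change rather than the same change. Because a number 0.8 percentage points lower from compound 1 to compound 2 (within the scatter) was within the scatter, a step of similar size, a number 0.4 percentage points lower from compound 3 to compound 4 (within the scatter), is expected for compound 4. Compound 4 is therefore estimated to give 53%, between 43% and 63%.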

Compound 4, a percentage reported as inhibition, in the whole organism at one dose (the size of the read-out at that dose, not a potency): 58.8%
For compound 4 the middle estimate is 5.8 percentage points below the measured one, within the range that was stated.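

In this assay, phenyl in place of formyl on the ring nitrogen gave a number 5.4 percentage points higher from compound 3 to compound 4 (within the scatter), and this step does not differ from the earlier one on the other core: the same change on two cores in this assay, a number 0.8 percentage points lower (within the scatter) from compound 1 to compound 2 and a number 5.4 percentage points higher (within the scatter) from compound 3 to compound 4, 6.2 percentage points apart, within the scatter of two such steps

Methyl in place of fluoro on an aromatic carbon, now read with phenyl on the ring nitrogen, gave a number 3.1 percentage points higher from compound 2 to compound 4 (within the scatter), and it also agrees with its earlier counterpart: the same change on two cores in this assay, a number 3.1 percentage points lower (within the scatter) from compound 1 to compound 3 and a number 3.1 percentage points higher (within the scatter) from compound 2 to compound 4, 6.2 percentage points apart, within the scatter of two such steps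

The change therefore carries between these two cores with no detectable difference, but with every step within the scatter, this shows no effect of the change on either core and says nothing about other cores.

The compounds shown carry only formyl or phenyl on that ring nitrogen, and only fluoro or methyl on that aromatic carbon. Going by these compounds, what an acetyl or benzyl group on the nitrogen, or a methoxy group on the aromatic carbon, would give remains open.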